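Flipping one ring stereocentre in a GCN2 kinase inhibitor

The source may hold more compounds than are shown below. What is called first, only, known or untested is meant among the compounds shown, and "the series" means these compounds.

Measured compounds:
Compound 1, `COCCNC(=O)CCNc1ncc2c(Br)nn(-c3ccc4ncccc4c3)c2n1`: "nd" (no result reported)
Compound 2, `COCCNC(=O)[C@H]1CC[C@@H](Nc2ncc3c(Br)nn(-c4ccc5ncccc5c4)c3n2)C1`: 156 nM

Compound 2 carries a saturated ring that links its amide to the shared core, and in an assay on SK-OV-3 cells for inhibition of eIF-2-alpha kinase GCN2 (Homo sapiens) (on this read-out higher numbers stand for weaker inhibition and lower numbers for stronger inhibition), compound 2 gives 156 nM. Among the measured compounds shown here, this is the only number available here; compound 1 was tested but no single number was obtained for it, so there is no measured step to compare against.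

Compound 3, `COCCNC(=O)[C@H]1CC[C@H](Nc2ncc3c(Br)nn(-c4ccc5ncccc5c4)c3n2)C1`, has the same atoms and bonds as compound 2 and differs from it only in configuration as drawn: the two compounds have the same atoms and bonds and differ only in configuration as drawn: 1 of 2 stereo elements differ; a stereocentre at a saturated ring carbon is drawn R in compound 2 and S in compound 3. For the measured compounds named here, changing the drawn configuration at one saturated ring carbon alters the shape of the molecule without changing any group, and no measured pair here shows how large such a change can be. The step from compound 2 to compound 3 is therefore expected to be modest and of uncertain direction, a 1.6-fold higher number from compound 2 to compound 3 (0.20 log units; within the scatter), with a wide range to allow for either outcome. Compound 3 is estimated at 250 nM, within roughly 50 nM to 1500 nM.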

Compound 3, half-maximal inhibitory concentration: 183 nM
For compound 3 the middle estimate is 1.4-fold (0.14 log units) above the measured one; the range from low to high includes it.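

In this assay, flipping this saturated ring carbon gives a 1.2-fold higher number from compound 2 to compound 3 (0.07 log units; within the scatter), so the two compounds cannot be told apart on this read-out. Among the compounds shown here, this is the only measured comparison here, and it is a clean one, since any gap between the two numbers can come only from the drawn configuration at that single carbon: the fact that compounds 2 and 3 differ only in the configuration as drawn. At this stereocentre, then, the R and S drawings give results that sit within the usual scatter of each other.

On these data alone, the second stereocentre is drawn the same way in both compounds, so the effect of flipping it remains open, as does the effect of flipping both together. Also open, as far as these compounds go, is how a carboxylic acid or a primary amine would fare in place of the methoxyethyl amide.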